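Methoxycarbonyl to Hydroxycarbamoyl on a Shared Core

This account rests on a few compounds, and the source may have more. Where it says the series, first, only, none or still open, it means among the compounds named here.

Three compounds have been measured so far:
compound 1 `COC(=O)c1ccc(OC)c(S(=O)(=O)Nc2ccc3c(c2)cc(C)c(=O)n3C)c1` gives 39% in a functional assay on HL-60 cells (Homo sapiens) for antiproliferative activity, tested at 4 uM; on this read-out higher numbers stand for a stronger effect at the one concentration tested and lower numbers for a weaker effect;
compound 2 `Cc1cc2cc(NS(=O)(=O)Cc3cccc(C(=O)NO)c3)ccc2n(C)c1=O` gives 0% in this assay;
compound 3 `COc1ccc(C(=O)NO)cc1CS(=O)(=O)Nc1ccc2c(c1)cc(C)c(=O)n2C` gives 0% in this assay.

Compound 1 stands highest of the three numbers. Compound 2 lies a stretch below it that is beyond the scatter, and compound 3 lies the same stretch below it, likewise beyond the scatter. For the measured compounds named here, the one measured step between neighbours, no change at the digits printed from compound 2 to compound 3 (within the scatter), comes with methoxy in place of hydrogen on an aromatic carbon and shows that this exchange leaves the read-out where it was.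

The compound not yet measured is compound 4 `COc1ccc(C(=O)NO)cc1S(=O)(=O)Nc1ccc2c(c1)cc(C)c(=O)n2C`. It differs from compound 1 in one place: hydroxyamino in place of methoxy on a carbonyl carbon. Going by the values given here, no measured step covers this exchange of methoxycarbonyl for hydroxycarbamoyl directly. What the data do show is that the two compounds carrying hydroxycarbamoyl, compound 2 and compound 3, both sit at the bottom of the range, though each also differs from compound 4 in another place, so their values bear on the question only loosely. On this basis the expected step from compound 1 to compound 4 is downward, a number 24 percentage points lower from compound 1 to compound 4 (beyond the scatter), with wide uncertainty. The estimate for compound 4 in this assay is 15%, expected to fall between 0% and 45%.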

Compound 4, a percentage reported as inhibition, at one concentration (the size of the read-out at that concentration, not a potency): 25%
Estimate against measurement, compound 4: 10 percentage points below; the measured number falls inside the stated range.
By their numbers in this assay, from the lowest: compounds 2 and 3 (each within the scatter of the next); then compound 4; then compound 1.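

In this assay, for the compounds shown here, replacing methoxycarbonyl with hydroxycarbamoyl on the shared core gives a number 14 percentage points lower from compound 1 to compound 4 (beyond the scatter), the first direct reading of this exchange at this carbonyl carbon, whose only other neighbour besides its oxygen is an aromatic carbon. The step is modest, yet compound 4 keeps a measurable effect of 25% while compound 3, which also carries hydroxycarbamoyl, gives 0% and differs from compound 4 in one other place, so among these compounds hydroxycarbamoyl does not by itself bring the number down to the bottom of the range. Nothing at hand accounts for the size of this step or for the retained effect of compound 4.

The compounds shown leave open how a carboxylic acid or a primary amide at the same carbonyl carbon would compare with methoxycarbonyl and hydroxycarbamoyl. They also leave open how compound 1 and compound 4 would compare across a range of concentrations, as each number here comes from a single concentration and is not a potency.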